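Imidazopyrazine series: para-bromo versus ortho-methoxy phenyl

The source may report more compounds than this note shows. Statements on the series, on what has been measured and on what is new or still open speak of the compounds shown alone.

Measured so far:
compound 1 `COc1ccc(-c2cn3ccnc3c(-c3ccc4ncn(C5CCCCC5)c4c3)n2)cc1` — -8.6%
compound 2 `Brc1ccc(-c2cn3ccnc3c(-c3ccc4ncn(C5CCCCC5)c4c3)n2)cc1` — 55%

In a functional assay on T47D cells (Homo sapiens) for inhibition, read by sulforhodamine B assay, with a stated time of 48 h, tested at 10 uM (a lower number here means less inhibition, a higher number more inhibition at the concentration tested (going by the name of the read-out)), compound 2 gives the higher of the two numbers; the nearest, compound 1, sits lower by a number 63.6 percentage points higher from compound 1 to compound 2 (beyond the scatter). Compound 3 `COc1ccccc1-c1cn2ccnc2c(-c2ccc3ncn(C4CCCCC4)c3c2)n1` is not yet measured. It differs from compound 2 by 2-methoxyphenyl in place of 4-bromophenyl on an aromatic carbon. For the measured compounds named here, only the step from compound 1 to compound 2 bears on it, and that step was large; it shows a methoxy-bearing phenyl far below the bromophenyl, though at a different position. A downward step is therefore expected in this assay, of roughly a number 40 percentage points lower from compound 2 to compound 3 (beyond the scatter). Compound 3 is estimated at 15%, range -10% to 45%.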

Compound 3, a percentage reported as inhibition, at one concentration (the size of the read-out at that concentration, not a potency): 36.6%
Beside the measured number, compound 3's estimate is 21.6 percentage points below it, within the range that was stated.
By their numbers in this assay, from the lowest: compound 1; then compound 3; then compound 2.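

In this assay the place of the methoxy group on the phenyl matters: 2-methoxyphenyl in place of 4-methoxyphenyl gives a number 45.2 percentage points higher from compound 1 to compound 3 (beyond the scatter), so a methoxy-bearing phenyl does not by itself mean a low number here. Against 4-bromophenyl, 2-methoxyphenyl gives a number 18.4 percentage points lower from compound 2 to compound 3 (beyond the scatter), which leaves compound 2 highest of the three. No measurement on hand explains either step.

From the compounds shown here alone, whether the number of compound 2 depends on the bromine or on its place stays open, as a 2-bromophenyl would show. Going by these compounds, how a 4-aminophenyl or 4-carboxyphenyl would read at this position also stays open.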